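The source may report more compounds than this note shows. Statements on the series, on what has been measured and on what is new or still open speak of the compounds shown alone.

In a functional assay on BT-474 cells (Homo sapiens) for inhibition, read by MTT assay, with a stated time of 5 days (on this read-out higher numbers stand for weaker inhibition and lower numbers for stronger inhibition), compound 1 `Cc1cc(Nc2nc(NCc3ccccc3Cl)nc3[nH]ncc23)n[nH]1` gives 7160 nM, compound 2 `Cc1cc(Nc2nc(NCc3cccc(Cl)c3)nc3[nH]ncc23)n[nH]1` gives 12900 nM, and compound 3 `Cc1cc(Nc2nc(NCc3ccc(F)cc3F)nc3[nH]ncc23)n[nH]1` gives 3220 nM. Compound 3 therefore has the lowest number of the three, with both of the others beyond the scatter from it.

Compound 4 `Cc1cc(Nc2nc(NCc3ccc(C#N)cc3)nc3[nH]ncc23)n[nH]1` differs from compound 3 as follows: 4-cyanophenyl in place of 2,4-difluorophenyl on a saturated chain carbon bound to a nitrogen on an aromatic ring. This puts 4-cyanophenyl in place of 2,4-difluorophenyl on a saturated chain carbon bound to a nitrogen on an aromatic ring.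

The measured steps at this same place are a 1.8-fold higher number from compound 1 to compound 2 (0.26 log units; within the scatter), a 2.2-fold lower number from compound 1 to compound 3 (0.35 log units; beyond the scatter) and a 4.0-fold lower number from compound 2 to compound 3 (0.60 log units; beyond the scatter). None of them involves a nitrile, so they indicate the size of change seen here, not its direction for this group. With compound 3 at the low end at 3220 nM, a modest move in this assay towards a higher number is expected, within the size of these steps.

The expected step is a 1.9-fold higher number from compound 3 to compound 4 (0.27 log units; within the scatter).

For compound 4, the estimated value is 6000 nM, with an expected range of 2200 nM to 15000 nM.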

Compound 4, half-maximal inhibitory concentration: 12100 nM
Beside the measured number, compound 4's estimate is 2.0-fold (0.30 log units) below it; low and high end bracket the measured number.
By their numbers in this assay, from the lowest: compound 3; then compounds 1, 4 and 2 (each within the scatter of the next).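

In this assay the swap of 2,4-difluorophenyl for 4-cyanophenyl gives a 3.8-fold higher number from compound 3 to compound 4 (0.57 log units; beyond the scatter) and so does not keep the low number of the difluorinated compound. Against the two chlorophenyl compounds the same group gives a 1.1-fold lower number from compound 2 to compound 4 (0.03 log units; within the scatter) and a 1.7-fold higher number from compound 1 to compound 4 (0.23 log units; within the scatter) and thus falls in with them, which leaves compound 3 alone at the low end of the four. Nothing measured here accounts for the separation of compound 3 from the other three.

Open, on these data alone, is whether the low number of compound 3 needs both fluorines, as a 4-fluorophenyl or 2-fluorophenyl group at this place would show. Also open, as far as these compounds go, is how an unsubstituted phenyl or a 4-methoxyphenyl group would stand against these four.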